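This account rests on a few compounds, and the source may have more. Where it says the series, first, only, none or still open, it means among the compounds named here.

Measured in a functional assay on MOLT-4 cells (Homo sapiens) for inhibition; a higher number here means a weaker inhibitor, a lower number a stronger inhibitor:
- compound 1 `O=C1/C(=C/c2ccc(F)cc2)Cc2ccccc21`: 60000 nM
- compound 2 `O=C1/C(=C/c2ccc(F)cc2)CCc2ccccc21`: 41200 nM
- compound 3 `O=C1/C(=C/c2ccc(Br)cc2)CCc2ccccc21`: > 500000 nM, a limit and not a number

Compound 3 stands only at a limit, with no number of its own: the limit of > 500000 nM in this assay, at which 1 of the 3 values shown sits.

The next compound, compound 4 `Cc1ccc(/C=C2\CCc3ccccc3C2=O)cc1`, changes a single group: methyl in place of bromo on an aromatic carbon. This puts methyl in place of bromo on an aromatic carbon, para to a large group. Within the data shown here, the only measured step at this place is the halogen exchange an at least 12-fold higher number from compound 2 to compound 3 (1.08 log units; beyond the scatter), which is large and beyond the scatter. That step went with the arrival of bromo, and compound 4 no longer carries it. On these data alone, no measurement covers methyl at this place, so the size of the step remains open. A clear step to a lower number is expected in this assay, possibly back toward compound 2 at 41200 nM. A second limit cannot be excluded.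

The estimated change is an at least 4.1-fold lower number from compound 3 to compound 4 (0.61 log units; beyond the scatter).

For compound 4 the expected value is 120000 nM, with an estimated range of 30000 nM to 500000 nM.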

Compound 4, half-maximal inhibitory concentration: > 500000 nM
Compound 4 ended at the assay's limit (the forecaster's own chance of this, stated with the estimate: 30%); at least 4.1-fold (0.61 log units) between middle value and limit.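

In this assay, methyl in place of fluoro gives an at least 12-fold higher number from compound 2 to compound 4 (1.08 log units; beyond the scatter), so the rise seen with bromo is not confined to bromo: two different replacements of fluoro at this place, on the aromatic carbon para to a large group, both leave the readable range. Among the compounds sharing the core of compound 2, only fluoro at this place gives a number, though two replacements are too few to call this a rule. The step between compound 3 and compound 4 cannot be read, and both compounds now stand at the same limit: the limit of > 500000 nM in this assay, at which 2 of the 4 values shown sit.

On these data alone, how far compound 3 and compound 4 lie from each other remains unknown. Also open, as far as these compounds go, is whether chloro, an unsubstituted ring carbon, methoxy or an amine at this place would give a number in this assay.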